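This account rests on a few compounds, and the source may have more. Where it says the series, first, only, none or still open, it means among the compounds named here.

Compounds measured in a physicochemical assay for solubility, read by mass spectrometry, in phosphate buffer, with a stated time of 24 h, at pH 7.4 (on this read-out higher numbers stand for higher solubility and lower numbers for lower solubility), so far
- Compound 1 `O=C(Nc1ccc(OC(F)(F)F)cc1)NC1CCN(C(=O)[C@@H]2CCOC2)CC1` gives 23 ug/mL
- Compound 2 `O=C(Nc1ccc(OC(F)(F)F)c(F)c1)NC1CCN(C(=O)C2CCCOC2)CC1` gives 174 ug/mL

Compound 2 at 174 ug/mL holds the higher of the two numbers, and compound 1 lies lower, beyond the scatter. Compound 3 `O=C(Nc1ccc(OC(F)(F)F)c(F)c1)NC1CCN(C(=O)[C@@H]2CCOC2)CC1` is not yet measured. It changes compound 2 as follows: oxolan-3-yl in place of oxan-3-yl on a carbonyl carbon with oxolan-3-yl in place of oxan-3-yl on a carbonyl carbon. Among the measured compounds shown here, no measured pair shows this change alone. Compound 1 also carries oxolan-3-yl and gives 23 ug/mL in this assay, so a moderate fall is expected. The expected size is a 2.2-fold lower number from compound 2 to compound 3 (0.34 log units; beyond the scatter) as estimated here. For compound 3 the estimated value is 80 ug/mL (range 30 ug/mL to 200 ug/mL) in this series.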

Compound 3, solubility: 61 ug/mL
For compound 3 the middle estimate is 1.3-fold (0.12 log units) above the measured one, within the range that was stated.
By their numbers in this assay, from the lowest: compound 1; then compound 3; then compound 2.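

In this assay the ring on the carbonyl carbon now has a single-change reading, with oxolan-3-yl in place of oxan-3-yl giving a 2.9-fold lower number from compound 2 to compound 3 (0.46 log units; beyond the scatter). With oxolan-3-yl held fixed, fluoro in place of hydrogen on an aromatic carbon gives a 2.7-fold higher number from compound 1 to compound 3 (0.42 log units; beyond the scatter), so each change has its own step, both beyond the scatter. No measurement shown gives a cause for either step. Still open, on these data alone, are the oxolan-3-yl with its stereocentre inverted and whether the ring step holds without the fluoro group. Also open, as far as these compounds go, is how an amine or a carboxylic acid on that ring would read.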